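Swapping an Acid-Bearing Ring for a Small Amide

The compounds below may be only part of what the source reports. "The series", "measured", "known", "first", "only" and "open" are said of these compounds alone.

In an assay (Rattus norvegicus) for inhibition of Fatty-acid amide hydrolase 1 (Homo sapiens) (on this read-out lower numbers stand for stronger inhibition and higher numbers for weaker inhibition), compound 2 `O=C(CCCCCCc1ccccc1)c1ncc(-c2ncccc2C(=O)O)o1` gives only a limit of > 50 nM, not a number. Compound 1 `Cc1ccnc(-c2cnc(C(=O)CCCCCCc3ccccc3)o2)c1` gives 0.6 nM in this assay. Among the measured compounds shown here, the one measured step, an at least 83-fold higher number from compound 1 to compound 2 (1.92 log units; beyond the scatter), is itself a floor, since compound 2 sits at the limit of > 50 nM in this assay, at which 1 of the 2 values shown sits. Compound 3 `CN(C)C(=O)c1cnc(C(=O)CCCCCCc2ccccc2)o1` differs from compound 2 by dimethylcarbamoyl in place of 3-carboxypyridin-2-yl on an aromatic carbon. The group whose arrival cost so much now leaves, so a clearly lower number is expected, though pyridyl also goes. Compound 3 is expected to give about 20 nM, between 3 nM and 150 nM, an expected step of an at least 2.5-fold lower number from compound 2 to compound 3 (0.39 log units; beyond the scatter).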

Compound 3, inhibition constant: 2 nM
Estimate against measurement, compound 3: 10-fold (1.00 log units) above; measured number outside the range, below it.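

Dimethylcarbamoyl, which has no ring, still gives a low number at this position: the change is a 3.3-fold higher number from compound 1 to compound 3 (0.52 log units; beyond the scatter). A ring here is therefore not required for strong inhibition in this pair. Replacing 3-carboxypyridin-2-yl gives an at least 25-fold lower number from compound 2 to compound 3 (1.39 log units; beyond the scatter), and this step is only a floor, because compound 2 has a limit and not a number: the limit of > 50 nM in this assay, at which 1 of the 3 values shown sits.

Going by these compounds, whether the ring or its acid drives the weak result of compound 2 stays open. A plain pyridin-2-yl and a carboxylic acid placed directly on this carbon would separate the two.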